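This account rests on a few compounds, and the source may have more. Where it says the series, first, only, none or still open, it means among the compounds named here.

The study concerns a small set of compounds sharing one core. Compound 1, with the structure `Oc1ccc(-c2cc(-c3ccsc3)cc(-c3cccc(O)c3)n2)cc1`, has in an assay on isolated protein for inhibition of DNA topoisomerase 1 (Homo sapiens), with a stated time of 30 min, tested at 20 uM (a higher number here means a stronger effect of the compound at the concentration tested, a lower number a weaker effect), the entry "not determined" (no result reported), so no number is available for it. Among the measured compounds shown here, compound 2, with the structure `Oc1ccc(-c2cc(-c3ccsc3)cc(-c3ccc(O)cc3)n2)cc1`, is the only compound with a number: in this assay compound 2 gives 7.5%, a weak effect at the tested concentration, and it is the sole point of reference available. Compound 3, with the structure `Oc1ccc(-c2cc(-c3ccco3)cc(-c3ccc(O)cc3)n2)cc1`, has not yet been tested.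

The change from compound 2 to compound 3 is furan-2-yl in place of thiophen-3-yl on an aromatic carbon. For the measured compounds named here, no step between two measured compounds is available, so nothing in the data shows whether exchanging one five-membered aromatic ring with one hetero atom for another moves the read-out.

Since compound 2 shows 7.5%, a weak effect that leaves little room to fall, the step from compound 2 to compound 3 is expected to be small and within the usual scatter, as a number 0.5 percentage points higher from compound 2 to compound 3 (within the scatter). Compound 3 is therefore estimated at 8%, with a range from 0% to 25%.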

Compound 3, a percentage reported as inhibition, at one concentration (the size of the read-out at that concentration, not a potency): 0%
Estimate against measurement, compound 3: 8 percentage points above; the measured number falls inside the stated range.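

In this assay, furan-2-yl in place of thiophen-3-yl on an aromatic carbon, opposite the ring nitrogen, gives a number 7.5 percentage points lower from compound 2 to compound 3 (within the scatter). This first readable step shows that exchanging one five-membered aromatic ring with 1 hetero atom for another at this position, with oxygen taking the place of sulfur and the point of attachment also differing, does not move the read-out beyond the usual scatter, and both compounds remain weak at the tested concentration. No available measurement accounts for this result or links it to a property of either ring.

The compounds shown leave open whether this position can influence the read-out at all, as a step between two weak compounds cannot separate a position that has no bearing on the read-out from two groups that simply fail to raise it. As far as these compounds go, it also remains open how thiophen-2-yl or furan-3-yl would read, which would separate the hetero atom from the point of attachment, and whether an amine, a carboxylic acid or a longer alkyl chain here would give a stronger effect than the two five-membered rings.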